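Dropping the Halogen: From Compound 2 to Compound 3

A few compounds are considered here, and "the series" means these few. Any claim that something is new, unique, unknown or untested is made for them only; others in the source may bear on it.

Of the compounds shown here, two of one shared core have been measured so far. Compound 1 `C=C1C[C@]23C[C@@]1(O)CC[C@@H]2c1cccc(C)c1[C@@H]3Cn1cc(-c2ccc(Cl)cc2)nn1` was tested in a functional assay on HL-60 cells (Homo sapiens) for cytotoxicity, read by MTT assay, with a stated time of 4 days (on this read-out lower numbers stand for stronger inhibition and higher numbers for weaker inhibition), and gives only a limit there, > 20000 nM. Compound 2 `C=C1C[C@]23C[C@@]1(O)CC[C@@H]2c1cccc(C)c1[C@@H]3Cn1cc(-c2ccc(Br)cc2)nn1` is reached by a step that the two limits leave unreadable from compound 1 to compound 2. In this assay compound 2 also gives only a limit, > 20000 nM. Among the measured compounds shown here, compound 2 thus sits at the limit of > 20000 nM in this assay, at which 2 of the 2 values shown sit; no number is known for it, and the one step that leads to it cannot be sized.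

Compound 3 `C=C1C[C@]23C[C@@]1(O)CC[C@@H]2c1cccc(C)c1[C@@H]3Cn1cc(-c2ccccc2)nn1` is not yet measured. It differs from compound 2 by hydrogen in place of bromo on an aromatic carbon. For the measured compounds named here, the only measured step that bears on this change is the one from compound 1 to compound 2, and it is unreadable, since both of its values are limits. Nothing in the data points to a reading below the limit, so compound 3 is expected to stay where compound 2 stands, with an estimate of 30000 nM and a range from 8000 nM to 100000 nM. The step this estimate means, a step that the limit leaves unreadable from compound 2 to compound 3, is expected to be none beyond the scatter.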

Compound 3, half-maximal inhibitory concentration: > 20000 nM
Compound 3: a limit, no number (the forecaster's own chance of this, stated with the estimate: 75%); the middle value does not contradict the limit.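

In this assay compound 3 gives > 20000 nM, a limit and not a number. Among the compounds shown here, no step among compound 1, compound 2 and compound 3 can therefore be read. The compounds shown leave open whether chloro, bromo or hydrogen on this aromatic carbon makes any difference to the value, as all of them end at one mark: the limit of > 20000 nM in this assay, at which 3 of the 3 values shown sit.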